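A few compounds are considered here, and "the series" means these few. Any claim that something is new, unique, unknown or untested is made for them only; others in the source may bear on it.

Measured so far in an assay on cells for displacement of a labelled ligand from transmembrane domain-containing protein TMIGD3 (Homo sapiens), read by scintillation counting, with a stated time of 120 min; on this read-out higher numbers stand for weaker inhibition and lower numbers for stronger inhibition:
compound 1 `O=C(Nc1nccn2cc(-c3ccccc3)nc12)c1ccccc1` gives 52 nM
compound 2 `Cc1ccc(C(=O)Nc2nc(-c3ccccc3)cn3cc(-c4ccccc4)nc23)cc1` gives 223 nM
compound 3 `O=C(Nc1nc(-c2ccccc2)cn2cc(-c3ccccc3)nc12)c1ccc(Cl)cc1` gives 156 nM

Compound 3 stands second highest of the three. Compound 2 is nearest; the step of a 1.4-fold lower number from compound 2 to compound 3 (0.16 log units; within the scatter) lies within the scatter. Compound 1 gives 52 nM, a lower number, and that gap goes beyond the scatter.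

Compound 4 `O=C(Nc1nc(-c2ccccc2)cn2cc(-c3ccccc3)nc12)c1ccco1` differs from compound 3 by furan-2-yl in place of 4-chlorophenyl on a carbonyl carbon. The only measured one-place step, a 1.4-fold lower number from compound 2 to compound 3 (0.16 log units; within the scatter), changes a substituent on the same ring and was within the scatter; no measured step exchanges the ring itself, so nothing shown bears directly on this change. In this assay the step of a 1.0-fold lower number from compound 3 to compound 4 (0.02 log units; within the scatter) is therefore expected, with no clear direction beyond the scatter. Compound 4 is estimated at 150 nM, range 50 nM to 500 nM.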

Compound 4, inhibition constant: 67 nM
The estimate for compound 4 lay 2.2-fold (0.35 log units) above the measured number, and the stated range covers the measured number.
By their numbers in this assay, from the lowest: compounds 1 and 4 (each within the scatter of the next); then compounds 3 and 2 (each within the scatter of the next).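

On the carbonyl carbon, exchanging the ring itself moves the number in this assay beyond the scatter, where the substituent change on the six-membered ring did not (a 1.4-fold lower number from compound 2 to compound 3 (0.16 log units; within the scatter)). Furan-2-yl gives a lower number than either 4-chlorophenyl (a 2.3-fold lower number from compound 3 to compound 4 (0.37 log units; beyond the scatter)) or 4-methylphenyl (a 3.3-fold lower number from compound 2 to compound 4 (0.52 log units; beyond the scatter)), though both steps are modest. Nothing measured here accounts for this change.

As far as these compounds go, whether the ring oxygen or the smaller ring size goes with the lower number stays open. Thiophen-2-yl or unsubstituted phenyl on the same carbonyl, with the rest of compound 4 unchanged, would separate the two.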